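The source may hold more compounds than are shown below. What is called first, only, known or untested is meant among the compounds shown, and "the series" means these compounds.

Measured so far:
Compound 1 `COc1cccc(C(O)CCn2nc3c(Br)c(Br)c(Br)c(Br)c3n2)c1` gives 48% in a functional assay on CCRF-CEM cells (Homo sapiens) for antiproliferative activity, read by MTT assay, with a stated time of 24 h, tested at 100 uM; a lower number here means a stronger effect, a higher number a weaker effect of the compound at the concentration tested.
Compound 2 `OC(CCn1nc2c(Br)c(Br)c(Br)c(Br)c2n1)c1ccccc1` gives 21% in this assay.

Going by the values given here, compound 2 stands lowest of the two numbers; its nearest neighbour is compound 1, and the single measured step, a number 27 percentage points lower from compound 1 to compound 2 (beyond the scatter), is a modest one that lies beyond the scatter. Since a lower number here means a stronger effect, compound 2 shows the stronger effect of the two.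

Compound 3 `CC(O)CCn1nc2c(Br)c(Br)c(Br)c(Br)c2n1` has not yet been measured in this assay. It differs from compound 2 in one place: methyl in place of phenyl on a saturated chain carbon bound to an oxygen on a saturated carbon and a saturated chain carbon. Among the compounds with values here, no measured step bears on this change. Within the data shown here, the only step known concerns a methoxy on an aromatic carbon of compound 1, far from the saturated chain carbon where the phenyl of compound 2 sits, so it gives no guide to the size or direction of the new step. With a whole aromatic ring removed and only a methyl left, the safest expectation is a weaker effect, seen as a higher number, but the range must stay wide. The estimated step is a number 21 percentage points higher from compound 2 to compound 3 (beyond the scatter). For compound 3 the expected value in this assay is 42%, ranging from 18% to 70%.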

Compound 3, a percentage reported as activity, at one concentration (the size of the read-out at that concentration, not a potency): 3%
Beside the measured number, compound 3's estimate is 39 percentage points above it, outside the stated range (below it).
By their numbers in this assay, from the lowest: compound 3; then compound 2; then compound 1.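

At the saturated chain carbon bound to an oxygen on a saturated carbon and a saturated chain carbon, an aromatic ring turns out not to be needed for the effect in this assay: methyl in place of phenyl gives a number 18 percentage points lower from compound 2 to compound 3 (beyond the scatter), and methyl in place of 3-methoxyphenyl gives a number 45 percentage points lower from compound 1 to compound 3 (beyond the scatter). Both steps run the same way, so among these compounds the one without a ring at this carbon, compound 3, shows the strongest effect, and the earlier methoxy comparison could not have revealed that the whole ring can go. Nothing at hand explains why the much smaller methyl outperforms either ring here.

The compounds shown leave open whether the trend continues with a plain hydrogen at this carbon or reverses with a longer chain such as ethyl or butyl, and whether an amine could take the place of the oxygen. From the compounds shown here alone, each compound is also read at one concentration only, so how the three compare in potency remains unknown.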